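Semicarbazone aryl variation in the shared core series

A few compounds are considered here, and "the series" means these few. Any claim that something is new, unique, unknown or untested is made for them only; others in the source may bear on it.

Compound 2 `CN(C)CCn1cnnc1-c1cc(Oc2ccc(NC(=O)N/N=C/c3c[nH]c4ccccc34)cc2F)ccn1` gives 1630 nM in a functional assay on NCI-H460 cells (Homo sapiens) for cytotoxicity, read by MTT assay, with a stated time of 72 h (on this read-out lower numbers stand for stronger inhibition and higher numbers for weaker inhibition), the higher of the two numbers seen so far. Among the compounds with values here, compound 1 `CN(C)CCn1cnnc1-c1cc(Oc2ccc(NC(=O)N/N=C/c3cccc(O)c3)cc2F)ccn1` gives 780 nM in this assay; the one measured step, a 2.1-fold higher number from compound 1 to compound 2 (0.32 log units; beyond the scatter), shows the 1H-indol-3-yl variant with the weaker read-out.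

Compound 3 `Cc1cc(/C=N/NC(=O)Nc2ccc(Oc3ccnc(-c4nncn4CCN(C)C)c3)c(F)c2)cc(C)c1O` differs from compound 2 in one place: 4-hydroxy-3,5-dimethylphenyl in place of 1H-indol-3-yl on a carbon with a double bond to nitrogen. The change bears on the same position as the measured step, and it brings back a hydroxyl-bearing six-membered carbon ring in place of the bicyclic group, so the step of a 2.1-fold higher number from compound 1 to compound 2 (0.32 log units; beyond the scatter) is the relevant precedent, read in the reverse direction. Within the data shown here, the added methyl groups on the entering ring have no counterpart among the measured compounds, so their contribution is unknown; the expectation rests on the hydroxyphenyl-to-indole exchange alone. Among the measured compounds shown here, a modest step to a lower number in this assay, of roughly the size of the one measured step, is therefore expected, that is a 2.0-fold lower number from compound 2 to compound 3 (0.31 log units; beyond the scatter).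

Compound 3 is estimated at 800 nM in this assay, within a range from 350 nM to 1900 nM.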

Compound 3, half-maximal inhibitory concentration: 2010 nM
Compound 3: middle estimate off by 2.5-fold (0.40 log units), on the low side; the whole stated range lies below it.
By their numbers in this assay, from the lowest: compound 1; then compounds 2 and 3 (each within the scatter of the next).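

Exchanging the bicyclic group for the substituted phenol leaves no readable difference in this assay: a 1.2-fold higher number from compound 2 to compound 3 (0.09 log units; within the scatter). Against compound 1, the same group gives a 2.6-fold higher number from compound 1 to compound 3 (0.41 log units; beyond the scatter), so a hydroxyl-bearing six-membered carbon ring on the carbon with a double bond to nitrogen does not by itself give the lower number of compound 1, and compound 3 goes against any reading of the first step as a simple hydroxyphenyl-versus-indole preference. No supporting data bear on why the 4-hydroxy-3,5-dimethylphenyl group reads with the indole rather than with the 3-hydroxyphenyl group.

The step from compound 1 to compound 3 alters the place of the hydroxyl and adds the two methyl groups in a single exchange, so the shares of these two differences cannot be separated from the compounds shown. Also open, from the compounds shown here alone, is how a plain phenyl group, or a phenyl group carrying an amine or a carboxylic acid, would read at this position relative to compound 1 and to compounds 2 and 3.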